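A few compounds are considered here, and "the series" means these few. Any claim that something is new, unique, unknown or untested is made for them only; others in the source may bear on it.

In a functional assay on HCC1806 cells (Homo sapiens) for inhibition, read by sulforhodamine B assay, tested at 10 uM (on this read-out lower numbers stand for less inhibition and higher numbers for more inhibition at the one concentration tested (going by the name of the read-out)), compound 2 `CN(C)c1ccc(C2CC(c3ccc(-n4cncn4)cc3)=NN2C(=O)c2cc(Cl)cc(Cl)c2)cc1` gives 5.3%, and compound 1 `CN(C)c1ccc(C2CC(c3ccc(-n4cncn4)cc3)=NN2)cc1` gives 6.8%; the two numbers lie within the scatter of each other, so compound 2 stands alongside compound 1 rather than apart from it. Going by the values given here, the one measured step, a number 1.5 percentage points lower from compound 1 to compound 2 (within the scatter), shows that attaching the (3,5-dichlorophenyl)carbonyl group to the amine nitrogen in the ring left the read-out where it was. Compound 3 `CN(C)c1ccc(C2CC(c3ccc(-n4cncn4)cc3)=NN2C(=O)/C=C/c2ccccc2)cc1` differs from compound 2 by 2-phenylethenyl in place of 3,5-dichlorophenyl on a carbonyl carbon. Among the compounds with values here, no measured pair exchanges one group on the carbonyl carbon for another, so that step bears only loosely on this change; it shows that the carbonyl substituent as a whole did not move the number. Compound 3 is therefore expected to stay near compound 2, with a step of a number 0.7 percentage points higher from compound 2 to compound 3 (within the scatter) in this assay, none beyond the scatter, and an estimated value of 6% within the range -4% to 18%.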

Compound 3, a percentage reported as inhibition, at one concentration (the size of the read-out at that concentration, not a potency): -3.7%
Compound 3: the middle estimate sits 9.7 percentage points above what was measured, and the stated range covers the measured number.
By their numbers in this assay, from the lowest: compounds 3, 2 and 1 (each within the scatter of the next, the first and the last beyond it).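

In this assay, 2-phenylethenyl in place of 3,5-dichlorophenyl on the carbonyl carbon comes with a number 9 percentage points lower from compound 2 to compound 3 (within the scatter), so this exchange does not separate the two amides. Going by these compounds alone, measured against the unsubstituted ring nitrogen, however, (2-phenylethenyl)carbonyl comes with a number 10.5 percentage points lower from compound 1 to compound 3 (beyond the scatter), the first step here to pass the scatter, although a modest one and one towards less inhibition. Nothing available explains this small shift.

Going by these compounds, whether an amine or a carboxylic acid on the carbonyl carbon, or a longer chain there, would move the number further in either direction remains open. The compounds shown also leave open whether any acyl group on this nitrogen can raise inhibition clearly above that of compound 1.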